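The compounds below may be only part of what the source reports. "The series", "measured", "known", "first", "only" and "open" are said of these compounds alone.

Measured so far:
compound 1 `CCN1C(=O)CN(S(=O)(=O)c2ccc(-n3nc(C(=O)O)cc3C)cc2)C1=S`: < 1%
compound 2 `C=CCN1C(=O)CN(S(=O)(=O)c2ccc(-n3nc(C)cc3C)cc2)C1=S`: 4%

Going by the values given here, in a functional assay on the whole organism (blood, strain albino) with Mus musculus as the target, with stated times of 6 days and 4 h, at a dose of 1 mmol/kg by the oral route (a lower number here means less inhibition, a higher number more inhibition at the dose given (going by the name of the read-out)), compound 2 gives 4%, the only number among the two values shown. Compound 1 gives a limit of the assay there, < 1%; this is the limit of < 1% in this assay, at which 1 of the 2 values shown sits. Compound 3 `C=CCN1C(=O)CN(S(=O)(=O)c2ccc(-n3nc(C(=O)O)cc3C)cc2)C1=S` differs from compound 2 in carboxy in place of methyl on an aromatic carbon. Among the compounds with values here, no measured step joins two compounds that differ in one place, so the data show nothing of what this change does. Both values shown sit at the bottom of the read-out. The step from compound 2 to compound 3 is expected to be none beyond the scatter, in either direction. Compound 3 is estimated at 2%, between 0% and 9%, an expected step of a number 2 percentage points lower from compound 2 to compound 3 (within the scatter).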

Compound 3, a percentage reported as inhibition, in the whole organism at one dose (the size of the read-out at that dose, not a potency): < 1%
Compound 3 was reported as a limit (the forecaster's own chance of this, stated with the estimate: 45%); middle value at least 1 percentage points away from the limit.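

In this assay compound 3 gives < 1%, a limit of the assay and not a number. Carboxy in place of methyl on an aromatic carbon gives a number at least 3 percentage points lower from compound 2 to compound 3 (that floor lies within the scatter), the first readable step at this position, and it shows no gain in inhibition with carboxy there. The step between compound 1 and compound 3 cannot be read, and the series stays at the bottom of the read-out: the limit of < 1% in this assay, at which 2 of the 3 values shown sit.

Going by these compounds, whether an amine or an ester on this aromatic carbon would raise inhibition remains open. So does the effect of a longer chain in place of the allyl group on the amide-type nitrogen.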